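Methyl for Nitro on a Chalcone-Bearing Anilide

The source may report more compounds than this note shows. Statements on the series, on what has been measured and on what is new or still open speak of the compounds shown alone.

Measured compounds:
compound 1 `Cc1cccc(NC(=O)CSC(=S)N[C@H]2CCOC2=O)c1`: 36600 nM
compound 2 `O=C(CSC(=S)N[C@H]1CCOC1=O)Nc1cccc([N+](=O)[O-])c1`: 58900 nM
compound 3 `O=C(CCl)Nc1ccc(C(=O)/C=C/c2ccc([N+](=O)[O-])cc2)cc1`: 2350 nM

All three were tested in a functional assay on MGC-803 cells (Homo sapiens) for cytotoxicity, read by MTT assay, with a stated time of 72 h; on this read-out higher numbers stand for weaker inhibition and lower numbers for stronger inhibition. Compound 2 and compound 1 share one core, and between them the change is methyl in place of nitro on an aromatic carbon, giving a 1.6-fold lower number from compound 2 to compound 1 (0.21 log units; within the scatter). Compound 3 stands apart: the difference between its core and that of compound 2 is not broken down here, but compound 3 gives the lowest number of the three.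

Compound 4 `Cc1ccc(/C=C/C(=O)c2ccc(NC(=O)CCl)cc2)cc1` is not yet measured. It differs from compound 3 by methyl in place of nitro on an aromatic carbon. This is the same kind of change as from compound 2 to compound 1, though the place is not identical: in the earlier pair the group sits meta to a large group, here it sits para to a large group.

Because the earlier step of a 1.6-fold lower number from compound 2 to compound 1 (0.21 log units; within the scatter) stayed within the scatter, a step of similar size is expected here, giving a 1.2-fold lower number from compound 3 to compound 4 (0.07 log units; within the scatter). Compound 4 is thus expected to give about 2000 nM, roughly between 800 nM and 6000 nM in this assay.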

Compound 4, half-maximal inhibitory concentration: 3600 nM
Compound 4: middle estimate off by 1.8-fold (0.26 log units), on the low side; measured number inside the range.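

In this assay, putting methyl in place of nitro on the core of compound 3 gave a 1.5-fold higher number from compound 3 to compound 4 (0.19 log units; within the scatter). Set beside the same swap on the other core, this step shows that the change carried over from one core to the other without a measurable difference: the same change on two cores in this assay, a 1.6-fold lower number (0.21 log units; within the scatter) from compound 2 to compound 1 and a 1.5-fold higher number (0.19 log units; within the scatter) from compound 3 to compound 4, 2.5-fold (0.39 log units) apart, within the scatter of two such steps So on both cores the swap stays within what repeated measurements would scatter by, but this does not prove that the swap has no effect, does not settle its direction, and rests on only two cores, with the group at a different place on each.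

The compounds shown leave open what other groups in this place, such as an amine or a carboxylic acid, would do in this assay, as only nitro and methyl appear there. Among the compounds shown here, they also include no pair linking the two cores by a single change, which leaves open what each part of the cores contributes.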